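The source may report more compounds than this note shows. Statements on the series, on what has been measured and on what is new or still open speak of the compounds shown alone.

Working notes on the series. In a functional assay on HeLa cells (Homo sapiens) for inhibition, read by CCK-8 assay, with a stated time of 72 h (on this read-out lower numbers stand for stronger inhibition and higher numbers for weaker inhibition), compound 1 `Cc1ccc(NS(=O)(=O)c2cccc(CCCCCCNC(=O)/C=C/c3cccnc3)c2)cc1` gives 38.8 nM, compound 3 `O=C(/C=C/c1cccnc1)NCCCCCCc1cccc(S(=O)(=O)Nc2ccc(Cl)cc2)c1` gives 170 nM and compound 2 `CC(C)(C)c1ccc(NS(=O)(=O)c2cccc(CCCCCCNC(=O)/C=C/c3cccnc3)c2)cc1` gives 1520 nM. Compound 3 therefore holds the middle of the three numbers. The next structure, compound 4 `O=C(/C=C/c1cccnc1)NCCCCCCc1cccc(S(=O)(=O)Nc2ccc(Oc3ccccc3)cc2)c1`, carries phenoxy in place of chloro on an aromatic carbon, para to a large group: phenoxy in place of chloro on an aromatic carbon.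

Going by the values given here, three measured steps bear on this place. Chloro in place of methyl gives a 4.4-fold higher number from compound 1 to compound 3 (0.64 log units; beyond the scatter), tert-butyl in place of methyl gives a 39-fold higher number from compound 1 to compound 2 (1.59 log units; beyond the scatter), and chloro in place of tert-butyl gives an 8.9-fold lower number from compound 2 to compound 3 (0.95 log units; beyond the scatter). Among the compounds with values here, no phenoxy compound has been measured, so the nearest guide is compound 2, the one measured case with a larger group, at 1520 nM. A modest rise in the number is therefore expected in this assay, though the direction remains uncertain. The expected change is a 3.2-fold higher number from compound 3 to compound 4 (0.51 log units; beyond the scatter). For compound 4 the estimated value is 550 nM, with an expected range of 130 nM to 2300 nM.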

Compound 4, half-maximal inhibitory concentration: 262 nM
Compound 4: middle estimate off by 2.1-fold (0.32 log units), on the high side; the range from low to high includes it.
By their numbers in this assay, from the lowest: compound 1; then compounds 3 and 4 (each within the scatter of the next); then compound 2.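

In this assay, phenoxy and chloro cannot be told apart at this place on the aromatic ring, despite the added aromatic ring and the 7 heavy atoms of phenoxy against 1 for chloro (a 1.5-fold higher number from compound 3 to compound 4 (0.19 log units; within the scatter)). Phenoxy, a large group, also stands well clear of tert-butyl (a 5.8-fold lower number from compound 2 to compound 4 (0.76 log units; beyond the scatter)), so the high number of compound 2 does not carry over to every large group here. Methyl keeps the lowest number of the four (a 6.8-fold higher number from compound 1 to compound 4 (0.83 log units; beyond the scatter)), and neither large group nor chloro matches it.

Still open, on these data alone, is whether a methoxy group, an amine or a carboxylic acid at this place would fall nearer compound 1 or compound 2, or pass methyl. Nothing available explains the differences between these groups.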